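The compounds below may be only part of what the source reports. "The series", "measured", "known", "first", "only" and "open" are said of these compounds alone.

Of the compounds shown here, two have been tested in a functional assay (trachea) with Rattus norvegicus as the target; a lower number here means a less potent compound, a higher number a more potent compound, by a factor of ten per unit of this negative logarithm. Compound 1 `CC1(C)C=C(n2ccccc2=O)c2cc(C(=O)c3ccccc3)ccc2O1` gives 6.21, the higher of the two numbers recorded. Compound 2 `CC1(C)C=C(n2ccccc2=O)c2cc(OC(=O)Nc3ccccc3F)ccc2O1` gives 4.22, which places compound 2 well below compound 1, further apart than the usual scatter of repeated measurements. The two differ in the group carried on the shared core, so the numbers alone show that this position matters a great deal to the read-out.

Compound 3 `CC1(C)C=C(n2ccccc2=O)c2cc(Br)ccc2O1` has not been measured yet. It differs from compound 1 in one place: bromo in place of benzoyl on an aromatic carbon. For the measured compounds named here, no measured pair shows exactly this change, so its effect is a matter of expectation. With a small single atom taking the place of the benzoyl group, a moderate drop is expected, though not one as deep as the gap to compound 2; the step of a number 0.71 log units lower from compound 1 to compound 3 (beyond the scatter) is estimated accordingly. Compound 3 is therefore expected to reach about 5.5, with a likely range from 4.6 to 6.4.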

Compound 3, logarithm of the reciprocal of the active concentration, log(1/C): 7.53
Beside the measured number, compound 3's estimate is 2.03 log units below it, and the stated range ends below it.
By their numbers in this assay, from the lowest: compound 2; then compound 1; then compound 3.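

In this assay, a high number at this position does not require the benzoyl group: with bromo in its place there is a number 1.32 log units higher from compound 1 to compound 3 (beyond the scatter), a large gain from a far smaller group. For the compounds shown here, the earlier pair showed only that the group on this aromatic carbon matters, whereas this change shows that the ring and carbonyl of benzoyl can both be removed with no loss, and that compound 1 was not the upper end for this series. Nothing measured here explains the rise.

Still open, going by these compounds, is whether the gain belongs to bromo itself or simply to the removal of benzoyl. Chloro, a methyl group, an amine or plain hydrogen on this same aromatic carbon would help to separate those two readings.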